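This account rests on a few compounds, and the source may have more. Where it says the series, first, only, none or still open, it means among the compounds named here.

In a functional assay on CEM/s cells (Homo sapiens) for cytotoxicity (on this read-out higher numbers stand for weaker inhibition and lower numbers for stronger inhibition), three related compounds have been measured so far. Compound 2 `C=CCn1c[n+](C/C=C(\C)CC/C=C(\C)CC/C=C(\C)CCC=C(C)C)c2/c(=N/OC)[nH]cnc21` gives 2940 nM, compound 3 `CO/N=c1\[nH]cnc2c1[n+](C/C=C(\C)CC/C=C(\C)CC/C=C(\C)CCC=C(C)C)cn2CCC#N` gives 5360 nM, and compound 1 `CC(C)=CCC/C(C)=C/CC/C(C)=C/CC/C(C)=C/C[n+]1cn(C)c2nc[nH]/c(=N\OCc3ccccc3)c21` gives 14000 nM. On these numbers compound 3 stands second highest of the three. For the measured compounds named here, the only step between compounds that differ in one place is a 1.8-fold higher number from compound 2 to compound 3 (0.26 log units; within the scatter), where cyanomethyl replaces vinyl on a saturated chain carbon bound to an aromatic nitrogen, a change that does not move the read-out beyond the scatter. Going by the values given here, compound 1 and compound 3 differ in two places at once, so no single step joins them; their values alone show that compound 1 gives a higher number than compound 3, a gap beyond the scatter.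

Compound 4 `CC(C)=CCC/C(C)=C/CC/C(C)=C/CC/C(C)=C/C[n+]1cn(CCC#N)c2nc[nH]/c(=N\OCc3ccccc3)c21` differs from compound 3 by phenyl in place of hydrogen on a saturated chain carbon bound to an oxygen, so methoxy becomes benzyloxy. Among the compounds with values here, no measured step isolates this change. It is, however, one of the two changes that separate compound 3 from compound 1, and compound 1 carries the higher number. On that basis the expected outcome is a rise of moderate size, a 1.9-fold higher number from compound 3 to compound 4 (0.27 log units; within the scatter). Compound 4 is therefore estimated at 10000 nM, with a plausible range from 4000 nM to 25000 nM.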

Compound 4, half-maximal inhibitory concentration: 19100 nM
The estimate for compound 4 lay 1.9-fold (0.28 log units) below the measured number, and the stated range covers the measured number.
By their numbers in this assay, from the lowest: compounds 2 and 3 (each within the scatter of the next); then compounds 1 and 4 (each within the scatter of the next).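

For the compounds shown here, putting phenyl on the saturated chain carbon bound to the oxygen, which turns methoxy into benzyloxy, gives a 3.6-fold higher number from compound 3 to compound 4 (0.55 log units; beyond the scatter) in this assay, the first single change here to move the number beyond the scatter, and the move is towards weaker inhibition. The other new step tests the aromatic nitrogen in the benzyloxy compounds: cyanomethyl in place of hydrogen on the saturated chain carbon bound to that nitrogen gives a 1.4-fold higher number from compound 1 to compound 4 (0.13 log units; within the scatter), so this change stays within the scatter, and the one-place change at that nitrogen among the methoxy compounds, a 1.8-fold higher number from compound 2 to compound 3 (0.26 log units; within the scatter), also stays within it. Among these few compounds, then, the read-out responds to the change at the oxygen and not to the two changes at the nitrogen, but nothing available says why the phenyl change has this effect.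

A single phenyl step cannot separate the effect of the aromatic ring from that of a larger group in general, and a longer saturated chain on the oxygen, such as propyl, would help to tell these apart. A benzyl ring carrying an amine or a carboxylic acid would show whether the ring tolerates further groups at all.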